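A few compounds are considered here, and "the series" means these few. Any claim that something is new, unique, unknown or untested is made for them only; others in the source may bear on it.

Compound 1 `CCNc1ccc2c(=O)oc(NC(C)C)nc2c1` and compound 2 `Cc1nc2c(C)cccc2c(=O)o1` share a fused core and have both been measured for lipophilicity. In a physicochemical assay for lipophilicity (on this read-out lower numbers stand for lower lipophilicity and higher numbers for higher lipophilicity), compound 1 gives 2.4, and compound 2 gives 2.1; the two numbers lie within the usual scatter of this assay, so neither compound can be said to be more or less lipophilic than the other. Compound 3 `CCc1ccc2c(=O)oc(NC(C)C)nc2c1` has not yet been measured. It differs from compound 1 in one place only: ethyl in place of ethylamino on an aromatic carbon. Going by the values given here, with no measured pair of this kind to lean on, the expectation rests on the change itself, in which a group with a hydrogen-bond donor and a hydrogen-bond acceptor gives way to one with neither. A moderate rise in this assay, beyond the scatter, is therefore expected, amounting to a number 0.70 log units higher from compound 1 to compound 3 (beyond the scatter). Compound 3 is expected to reach about 3.1, most likely between 2.6 and 3.6.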

Compound 3, distribution coefficient: 3.2
Compound 3: the middle estimate sits 0.10 log units below what was measured; low and high end bracket the measured number.
By their numbers in this assay, from the lowest: compounds 2 and 1 (each within the scatter of the next); then compound 3.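

On this aromatic carbon, ethyl in place of ethylamino gives, in this assay, a number 0.80 log units higher from compound 1 to compound 3 (beyond the scatter). Going by these compounds alone, compounds 1 and 2 differ in more than one place and their numbers lie within the scatter, so this is the first step here that ties a clear difference in this read-out to a single change: ethylamino carries a hydrogen-bond donor and a hydrogen-bond acceptor, whereas ethyl has neither. Still, no measurement shown explains why the number moves as it does.

A single pair cannot show how much depends on the nitrogen and how much on the chain attached to it. Going by these compounds, a plain amine, a methoxy group or a longer chain such as propyl on the same carbon would help to separate the two, and whether the step carries over to other substituents on the shared core remains open.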